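This account rests on a few compounds, and the source may have more. Where it says the series, first, only, none or still open, it means among the compounds named here.

In a physicochemical assay for solubility, in phosphate buffer (on this read-out higher numbers stand for higher solubility and lower numbers for lower solubility), compound 1 `CCOC(=O)c1ccc(Nc2cc(C)nc(-c3ccncc3)n2)cc1` gives 4000 nM and compound 2 `CC(=O)c1ccc(Nc2cc(C)nc(-c3ccncc3)n2)cc1` gives 6000 nM. The swap between them, methyl in place of ethoxy on a carbonyl carbon, is a 1.5-fold higher number from compound 1 to compound 2 (0.18 log units; within the scatter). Compound 3 `CCOC(=O)c1cccc(Nc2ccnc(-c3cccnc3)n2)c1` gives 92000 nM, which leaves compound 2 well short of the top of this small set. Compound 4 `CC(=O)c1ccc(Nc2cc(C)nc(-c3cccnc3)n2)cc1` differs from compound 2 by one change: pyridin-3-yl in place of pyridin-4-yl on an aromatic carbon. Within the data shown here, no measured step isolates this change. Compound 3 also carries pyridin-3-yl, but it differs elsewhere too, so its 92000 nM offers only a weak hint of a rise. The expected change is small, a 1.5-fold higher number from compound 2 to compound 4 (0.18 log units; within the scatter), and may not clear the scatter. For compound 4, the estimated value is 9000 nM, with an expected range of 3000 nM to 30000 nM.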

Compound 4, solubility: 94000 nM
The estimate for compound 4 lay 10-fold (1.02 log units) below the measured number, and the stated range ends below it.
By their numbers in this assay, from the lowest: compounds 1 and 2 (each within the scatter of the next); then compounds 3 and 4 (each within the scatter of the next).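

In this assay, among these compounds, pyridin-3-yl in place of pyridin-4-yl on this aromatic carbon gives a 16-fold higher number from compound 2 to compound 4 (1.19 log units; beyond the scatter), the first measured step that isolates this change. The two groups have the same atoms and the same counts of donors and acceptors, so in this pair a change in how the same atoms are joined is enough for a large step. Nothing measured here explains the rise. From the compounds shown here alone, whether the same swap does as much with the ethyl ester of compound 1 remains open. So does what pyridin-2-yl, or a pyridine ring carrying an amine, would give on this carbon.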